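The compounds below may be only part of what the source reports. "The series", "measured", "known", "first", "only" and "open" are said of these compounds alone.

Measured compounds: compound 1 `CCCCC#Cc1ccc(S(=O)(=O)Nc2cccc(-c3csc(NC(C)=O)n3)c2)cc1` gives < 1%; compound 2 `CC(=O)Nc1nc(-c2cccc(NS(=O)(=O)c3cccc(C#C[Si](C)(C)C)c3)c2)cs1` gives 5.8%.

In a functional assay on A-375 cells (Homo sapiens) for antiproliferative activity, read by trypan blue exclusion, with a stated time of 48 h, tested at 10 uM (a lower number here means a stronger effect, a higher number a weaker effect of the compound at the concentration tested), compound 1 reaches only a limit of the assay, not a number, namely < 1%; this is the limit of < 1% in this assay, at which 1 of the 2 values shown sits. Compound 2, in this assay, gives 5.8%. The unmeasured compound 3 `CCCCCC/C=C\c1ccc(S(=O)(=O)Nc2cccc(-c3csc(NC(C)=O)n3)c2)cc1` differs from compound 1 at one spot: a group of 8 heavy atoms (8 carbon; no ring) in place of a group of 6 heavy atoms (6 carbon; no ring), on an aromatic carbon. Among the compounds with values here, no measured step links the two, so in this assay no change beyond the usual scatter is expected. Compound 3 is therefore estimated at 3%, within 0% to 15%, and the expected step is a number at least 2 percentage points higher from compound 1 to compound 3 (that floor lies within the scatter).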

Compound 3, a percentage reported as activity, at one concentration (the size of the read-out at that concentration, not a potency): <= 1%
Compound 3: only a limit was reported; the forecaster's own chance of this, stated with the estimate: 40%; middle value at least 2 percentage points away from the limit.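

In this assay compound 3 gives <= 1%, which is a limit of the assay. Compound 1 gives < 1%, also a limit, so no step can be read between compound 1 and compound 3. The compounds shown leave open whether replacing hex-1-yn-1-yl with the group in compound 3 changes the antiproliferative read-out at all.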